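Replacing 2-fluorophenyl with 3-ethynylphenyl on a carbonyl carbon

The source may report more compounds than this note shows. Statements on the series, on what has been measured and on what is new or still open speak of the compounds shown alone.

In an ADME assay on microsomes from liver (Rattus norvegicus) for pharmacokinetics (a higher number here means faster removal of the compound, a lower number slower removal), compound 1 `Cc1ccc(S(=O)(=O)N[C@@H](CC(=O)NC(C)(C)C)C(=O)NCCNC(=O)c2ccccc2)cc1` gives 66 mL.min-1.g-1, and compound 2 `Cc1ccc(S(=O)(=O)N[C@@H](CC(=O)NC(C)(C)C)C(=O)NCCNC(=O)c2ccccc2F)cc1` gives 124 mL.min-1.g-1. Compound 2 has a single measured neighbour on this scale, and the two numbers lie within the usual scatter of each other. Within the data shown here, the one measured step is a 1.9-fold higher number from compound 1 to compound 2 (0.27 log units; within the scatter), and it consists of fluoro in place of hydrogen on an aromatic carbon.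

Compound 3 `C#Cc1cccc(C(=O)NCCNC(=O)[C@H](CC(=O)NC(C)(C)C)NS(=O)(=O)c2ccc(C)cc2)c1` has not yet been measured. Its difference from compound 2 is 3-ethynylphenyl in place of 2-fluorophenyl on a carbonyl carbon, which amounts to 3-ethynylphenyl in place of 2-fluorophenyl on a carbonyl carbon. Among the measured compounds shown here, no measured compound carries the 3-ethynylphenyl group, and the data hold no direct evidence on it. For the measured compounds named here, the only guide is the change on the aromatic ring in the step from compound 1 to compound 2, which stayed within the scatter at a 1.9-fold higher number from compound 1 to compound 2 (0.27 log units; within the scatter). On that slender basis, no step beyond the scatter is expected in this assay, in either direction. The expected step is a 1.2-fold lower number from compound 2 to compound 3 (0.09 log units; within the scatter). Compound 3 is estimated at 100 mL.min-1.g-1, with an expected range from 50 mL.min-1.g-1 to 200 mL.min-1.g-1.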

Compound 3, intrinsic clearance in microsomes: 61 mL.min-1.g-1
Beside the measured number, compound 3's estimate is 1.6-fold (0.21 log units) above it, within the range that was stated.
By their numbers in this assay, from the lowest: compounds 3, 1 and 2 (each within the scatter of the next, the first and the last beyond it).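

In this assay, 3-ethynylphenyl in place of 2-fluorophenyl on a carbonyl carbon gives a 2.0-fold lower number from compound 2 to compound 3 (0.31 log units; beyond the scatter), a modest step and the first among these compounds to pass beyond the scatter. Adding an ethynyl group to the ring gives a 1.1-fold lower number from compound 1 to compound 3 (0.03 log units; within the scatter), so this larger ring group, with its triple bond, stays within the scatter of the unsubstituted ring, as fluoro does in a 1.9-fold higher number from compound 1 to compound 2 (0.27 log units; within the scatter), and the one step beyond the scatter arises only when the two substituted rings are set against each other. Nothing available explains why the two substituted rings stand apart in this measure.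

The compounds shown carry only fluoro and ethynyl on this ring, so what an amine, a carboxylic acid or a longer chain such as propynyl would do to the number in this assay remains open. Nor can the identity of a ring group be told apart from its place on the ring, since 2-fluorophenyl and 3-ethynylphenyl differ in both.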